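Benzimidazole-to-benzoxazolone swap on the acetamide arm

A few compounds are considered here, and "the series" means these few. Any claim that something is new, unique, unknown or untested is made for them only; others in the source may bear on it.

Within the data shown here, compound 2 `CCOc1ncc(-c2nc(C(F)(F)F)sc2N2CCN(C(=O)Cn3cnc4ccccc43)[C@H](C)C2)cn1` holds the lower of the two values measured so far in a functional assay on U2OS cells for antagonist activity at C-X-C chemokine receptor type 3 (Homo sapiens), read by beta-arrestin recruitment; a lower number here means a stronger inhibitor, a higher number a weaker inhibitor: compound 2 gives 49 nM. The other measured member, compound 1 `C[C@@H]1CN(c2sc(CN(C)C)nc2-c2nc3ccccc3[nH]2)CCN1C(=O)Cn1cnc2cccnc21`, in this assay gives 2360 nM, a gap beyond the usual scatter; compound 1 and compound 2 differ in several places at once, so no single-point comparison can be drawn from that pair.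

Compound 3 `CCOc1ncc(-c2nc(C(F)(F)F)sc2N2CCN(C(=O)Cn3c(=O)oc4ccccc43)[C@H](C)C2)cn1` is the next member. It differs from compound 2 by a group of 10 heavy atoms (7 carbon, 1 nitrogen, 2 oxygen; one five-membered aromatic ring with 2 hetero atoms, one six-membered aromatic ring of carbon only) in place of a group of 9 heavy atoms (7 carbon, 2 nitrogen; one five-membered aromatic ring with 2 hetero atoms, one six-membered aromatic ring of carbon only), on a saturated chain carbon bound to a carbonyl carbon. Among the measured compounds shown here, no measured pair shows this change on its own, so its size in this assay has to be estimated without a direct precedent. The acyl chain and the core of compound 2 are kept, and the group that enters is of comparable atom count to the one that leaves, so the step is expected to be modest, most likely toward a weaker inhibitor, though a change within the scatter is also plausible. The expected step from compound 2 to compound 3 is a 2.2-fold higher number from compound 2 to compound 3 (0.35 log units; beyond the scatter). Compound 3 is estimated at 110 nM in this assay, with a range from 30 nM to 450 nM.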

Compound 3, half-maximal inhibitory concentration: 99 nM
Estimate against measurement, compound 3: 1.1-fold (0.05 log units) above; the measured number falls inside the stated range.
By their numbers in this assay, from the lowest: compound 2; then compound 3; then compound 1.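

In this assay, among these compounds, the exchange of 1H-benzimidazol-1-yl for the benzoxazolone group, on a saturated chain carbon bound to a carbonyl carbon, gives a 2.0-fold higher number from compound 2 to compound 3 (0.31 log units; beyond the scatter) with the rest of the molecule unchanged, the first single-point reading at this position. The step is modest, so this position accepts a second fused bicyclic group with only a small loss, while the count of hydrogen-bond acceptors rises, a double bond outside aromatic rings appears, and there are still no hydrogen-bond donors and no net charge. These features all change in one step and cannot be separated here, and no measurement on hand accounts for the loss.

The compounds shown leave open whether the step follows the added carbonyl oxygen or the exchange of a ring nitrogen for a ring oxygen, and whether it would hold on the core of compound 1. They also leave open how this position responds to a group of a different kind, such as a simple phenyl ring, a primary amine or a carboxylic acid, or to a longer chain ahead of the bicyclic group.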